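The source may report more compounds than this note shows. Statements on the series, on what has been measured and on what is new or still open speak of the compounds shown alone.

Measured so far in a functional assay on Bel-7402 cells (Homo sapiens) for inhibition, read by MTT assay; on this read-out higher numbers stand for weaker inhibition and lower numbers for stronger inhibition
Compound 1 `C=C1C(=O)[C@@]23C(=O)OC[C@]4([C@@H](OC(C)=O)CCC(C)(C)[C@H]4C=O)[C@@H]2CC[C@H]1[C@H]3OC(=O)CC` gives 3780 nM
Compound 2 `C=C1C(=O)[C@@]23C(=O)OC[C@]4([C@@H](OC(C)=O)CCC(C)(C)[C@H]4C=O)[C@@H]2CC[C@H]1[C@H]3OC(=O)c1ccc(Cl)cc1` gives 1510 nM
Compound 3 `C=C1C(=O)[C@@]23C(=O)OC[C@]4([C@@H](OC(C)=O)CCC(C)(C)[C@H]4C=O)[C@@H]2CC[C@H]1[C@H]3OC(=O)c1ccc(C(F)(F)F)cc1` gives 5090 nM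

Compound 2 stands lowest of the three (1510 nM), and its gaps to the other two lie beyond the scatter. On the carbonyl carbon that carries the varied group, 4-chlorophenyl in place of ethyl gave a modest change (a 2.5-fold lower number from compound 1 to compound 2 (0.40 log units; beyond the scatter)). 4-(trifluoromethyl)phenyl in place of ethyl gave no change beyond the scatter (a 1.3-fold higher number from compound 1 to compound 3 (0.13 log units; within the scatter)). Trifluoromethyl in place of chloro on an aromatic carbon gave another modest change (a 3.4-fold higher number from compound 2 to compound 3 (0.53 log units; beyond the scatter)).

Compound 4 (`C=C1C(=O)[C@@]23C(=O)OC[C@]4([C@@H](OC(C)=O)CCC(C)(C)[C@H]4C=O)[C@@H]2CC[C@H]1[C@H]3OC(=O)c1ccccc1Cl`) has not yet been measured. It carries 2-chlorophenyl in place of 4-chlorophenyl on a carbonyl carbon. Within the data shown here, no measured step moves the chloro group around the aromatic ring, so the evidence is indirect. The measured steps at this carbonyl carbon are all modest or within the scatter, which gives no reason to expect a large jump. Among the measured compounds shown here, compound 2 also holds the lowest number of the set, and its one measured aromatic change raised the number (a 3.4-fold higher number from compound 2 to compound 3 (0.53 log units; beyond the scatter)). The expected step in this assay is therefore small and toward a higher number (a 1.7-fold higher number from compound 2 to compound 4 (0.22 log units; within the scatter)). Compound 4 is estimated at 2500 nM (expected range 1000 nM to 6000 nM).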

Compound 4, half-maximal inhibitory concentration: 1390 nM
Compound 4: the middle estimate sits 1.8-fold (0.25 log units) above what was measured; the range from low to high includes it.
By their numbers in this assay, from the lowest: compounds 4 and 2 (each within the scatter of the next); then compounds 1 and 3 (each within the scatter of the next).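

In this assay, 2-chlorophenyl in place of 4-chlorophenyl on the carbonyl carbon leaves the read-out within the scatter (a 1.1-fold lower number from compound 2 to compound 4 (0.04 log units; within the scatter)), so in this pair the two chlorophenyl groups cannot be told apart. The gaps to the other two compounds lie beyond the scatter for 2-chlorophenyl as well, both in place of ethyl (a 2.7-fold lower number from compound 1 to compound 4 (0.43 log units; beyond the scatter)) and in place of 4-(trifluoromethyl)phenyl (a 3.7-fold lower number from compound 3 to compound 4 (0.56 log units; beyond the scatter)), so across these four compounds the lower numbers go with the two chlorophenyl groups, while compound 3, which also carries an aromatic ring, goes against any reading that such a ring alone lowers the number. Nothing available here explains why these groups differ or why the two chlorophenyl groups read alike.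

On these data alone, it remains open whether a plain phenyl or a 4-methoxyphenyl group on this carbonyl carbon would read like the chlorophenyl compounds or like compound 3. As far as these compounds go, it is also open whether 3-chlorophenyl would continue the match between the two chlorophenyl groups, and whether a longer alkyl chain in place of ethyl would shift the number.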